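Fused-ring series at the assay limit: alkyl branching steps

A few compounds are considered here, and "the series" means these few. Any claim that something is new, unique, unknown or untested is made for them only; others in the source may bear on it.

Compound 1 `CCc1ncn2c(S)nncc12`: in a functional assay for inhibition, with Homo sapiens as the target (a higher number here means a weaker inhibitor, a lower number a stronger inhibitor), compound 1 gives only the assay limit > 48000 nM.
Compound 2 `CCCc1nc(C)c2c(CC)nnc(S)n12`: in this assay compound 2 gives only the assay limit > 48000 nM.
Compound 3 `Cc1ncn2c(S)nncc12`: in this assay compound 3 gives only the assay limit > 48000 nM.

All three measured values sit at one and the same limit (the limit of > 48000 nM in this assay, at which 3 of the 3 values shown sit), so no number exists for any of them. Compound 3 to compound 1 is methyl in place of hydrogen on a saturated chain carbon bound to an aromatic carbon; both ends are limits and the step that the two limits leave unreadable from compound 3 to compound 1 cannot be read. Compound 2 and compound 3 show no single counted difference; the difference between the two cores is not broken down here.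

Compound 4 `CCc1nnc(S)n2c(C(C)CC)nc(C)c12`, not yet measured, differs from compound 2 by methyl in place of hydrogen on a saturated chain carbon bound to an aromatic carbon and a saturated chain carbon. This is the same kind of change as from compound 3 to compound 1, but the place is not the same word for word: in compound 2 the saturated chain carbon is bound to an aromatic carbon and a saturated chain carbon, in compound 3 to an aromatic carbon only; one bond further out it reads propyl to sec-butyl rather than methyl to ethyl.

The step from compound 2 to compound 4 is expected to be a step that the limit leaves unreadable from compound 2 to compound 4. This expectation rests on compound 1, compound 2 and compound 3 all sitting at the limit (the limit of > 48000 nM in this assay, at which 3 of the 3 values shown sit), with no readable precedent for the change. Compound 4 is therefore estimated at 70000 nM, between 30000 nM and 200000 nM, most likely again reported only as a limit.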

Compound 4, half-maximal inhibitory concentration: > 48000 nM
Compound 4: no number, only a limit; the forecaster's own chance of this, stated with the estimate: 85%; the middle value is on the limit's open side.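

Compound 4, like compound 2, gives only a limit and no number, so no new step can be read between them: the limit of > 48000 nM in this assay, at which 4 of the 4 values shown sit.

The compounds shown leave open how strongly any of compounds 1 to 4 inhibits, and whether methyl in place of hydrogen on a saturated chain carbon changes the read-out at all.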